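Shared core: moving the chlorine on the aryl group

This account rests on a few compounds, and the source may have more. Where it says the series, first, only, none or still open, it means among the compounds named here.

Compound 1 `Oc1cccc(-c2cc(-c3ccc(Cl)cc3)nc(-c3cccs3)c2)c1` is measured in an assay on isolated protein for inhibition of DNA topoisomerase 1 (Homo sapiens), with a stated time of 30 min, tested at 100 uM (a lower number here means a weaker effect, a higher number a stronger effect of the compound at the concentration tested), where compound 1 gives 15.1%. Compound 2 `Oc1cccc(-c2cc(-c3ccc(Cl)cc3)nc(-c3ccsc3)c2)c1` gives 11.7% in this assay. The only step between measured compounds, a number 3.4 percentage points lower from compound 1 to compound 2 (within the scatter), is within the scatter, so compound 1 and compound 2 cannot be told apart on the numbers shown; compound 1 serves as the reference for the next step. Compound 3 `Oc1cccc(-c2cc(-c3cccc(Cl)c3)nc(-c3cccs3)c2)c1` differs from compound 1 by 3-chlorophenyl in place of 4-chlorophenyl on an aromatic carbon. Going by the values given here, no measured step touches this part of the structure: the step of a number 3.4 percentage points lower from compound 1 to compound 2 (within the scatter) puts thiophen-3-yl in place of thiophen-2-yl and leaves the chlorophenyl group untouched, so it gives no direct guide to direction. Its small size suggests that a single change of this kind has not moved this assay beyond the scatter, and the expected step of a number 1.1 percentage points lower from compound 1 to compound 3 (within the scatter) is likewise small. For compound 3 the estimate in this assay is 14%, with a range from 4% to 28%.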

Compound 3, a percentage reported as inhibition, at one concentration (the size of the read-out at that concentration, not a potency): 7.6%
The estimate for compound 3 lay 6.4 percentage points above the measured number, within the range that was stated.
By their numbers in this assay, from the lowest: compounds 3, 2 and 1 (each within the scatter of the next).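

Moving the chlorine gives the first measured step at the chlorophenyl group: in this assay there is a number 7.5 percentage points lower from compound 1 to compound 3 (within the scatter). On these numbers, 3-chlorophenyl and 4-chlorophenyl at this aromatic carbon next to the ring nitrogen cannot be told apart, so this change joins the thiophene change, with a number 3.4 percentage points lower from compound 1 to compound 2 (within the scatter), as a step that stays inside the scatter. No measurement available here offers an explanation for the values at this position.

Whether the chlorine itself matters remains open, since the series shown holds no unsubstituted phenyl group and no methoxy or amino group on this ring. On these data alone, it also remains open whether any single change to the aryl group can move this read-out beyond the scatter.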